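The source may hold more compounds than are shown below. What is called first, only, known or untested is meant among the compounds shown, and "the series" means these compounds.

Compound 1 `Cc1cc(NC(=O)Nc2cccc(C(F)(F)F)c2)c2ccccc2n1` carries a trifluoromethyl group on one aromatic ring, and in an ADME assay on Raji cells (Homo sapiens) for cytotoxicity, with a stated time of 72 h (a lower number here means that less compound is needed, a higher number that more compound is needed for the effect), compound 1 gives 10000 nM. Compound 2 `COc1cccc(NC(=O)Nc2cc(C)nc3ccccc23)c1` carries a methoxy group in its place. In this assay compound 2 gives only a limit, > 25000 nM. Compound 3 `COc1ccc(NC(=O)Nc2cc(C)nc3ccccc23)cc1OC` adds a second methoxy group. In this assay compound 3 likewise gives only a limit, > 25000 nM. The first change gave an at least 2.5-fold higher number from compound 1 to compound 2 (0.39 log units; beyond the scatter); the second gave a step that the two limits leave unreadable from compound 2 to compound 3, since both values sit at the limit of > 25000 nM in this assay, at which 2 of the 3 values shown sit. Compound 4 `Cc1cc(NC(=O)Nc2cccc(N(C)C)c2)c2ccccc2n1` differs from compound 2 by dimethylamino in place of methoxy on an aromatic carbon. Within the data shown here, no measured step compares these two groups, so the expected step is a step that the limit leaves unreadable from compound 2 to compound 4, with no shift beyond the scatter. Compound 4 is therefore estimated at 30000 nM, between 12000 nM and 80000 nM.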

Compound 4, half-maximal effective concentration: > 25000 nM
Compound 4: only a limit was reported (the forecaster's own chance of this, stated with the estimate: 60%); the middle value does not contradict the limit.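

Dimethylamino at this place behaves like methoxy: compound 4 also gives only a limit, so a second group in place of trifluoromethyl gives an at least 2.5-fold higher number from compound 1 to compound 4 (0.39 log units; beyond the scatter) in this assay. Among these compounds, compound 1 thus remains the only compound here with a number rather than a limit. The steps among compound 2, compound 3 and compound 4 cannot be read, because these values all stop at the same limit: the limit of > 25000 nM in this assay, at which 3 of the 4 values shown sit.

Going by these compounds, whether methoxy or dimethylamino differ at all stays open. So does whether a chlorine atom, a nitrile or a carboxylic acid at this place would give a number rather than a limit.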